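Compound 3 to compound 4: lengthening the imidazole chain

The source may report more compounds than this note shows. Statements on the series, on what has been measured and on what is new or still open speak of the compounds shown alone.

In a functional assay for inhibition, with Homo sapiens as the target (on this read-out lower numbers stand for stronger inhibition and higher numbers for weaker inhibition), the measured compounds read as follows
- compound 1 `O=C(NC[C@H](NS(=O)(=O)c1ccccc1)C(=O)O)c1cc2cc(OCC3CCNCC3)ccc2[nH]1` gives 13 nM
- compound 2 `O=C(NC[C@H](NS(=O)(=O)c1ccccc1)C(=O)O)c1cc2cc(OCc3ccncc3)ccc2[nH]1` gives 280 nM
- compound 3 `O=C(NC[C@H](NS(=O)(=O)c1ccccc1)C(=O)O)c1cc2cc(OCCn3ccnc3)ccc2[nH]1` gives 45 nM

Compound 3 at 45 nM stands second highest of the three numbers, with a 3.5-fold higher number from compound 1 to compound 3 (0.54 log units; beyond the scatter) on one side and a 6.2-fold lower number from compound 2 to compound 3 (0.79 log units; beyond the scatter) on the other. Going by these compounds, compound 4 `O=C(NC[C@H](NS(=O)(=O)c1ccccc1)C(=O)O)c1cc2cc(OCCCc3c[nH]cn3)ccc2[nH]1` is still open, and (1H-imidazol-4-yl)methyl in place of 1H-imidazol-1-yl on a saturated chain carbon, two bonds along the chain from an oxygen on an aromatic ring is its difference. Within the data shown here, no measured step alters only the chain or the imidazole attachment. All measured steps replace the ring group, the largest being a 22-fold higher number from compound 1 to compound 2 (1.33 log units; beyond the scatter) whereas an imidazole stays here, so a smaller step is expected in this assay with its direction open, possibly none beyond the scatter. The expected step is a 1.1-fold lower number from compound 3 to compound 4 (0.05 log units; within the scatter) by estimate. Compound 4 is estimated at 40 nM with 12 nM to 130 nM as the expected range.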

Compound 4, half-maximal inhibitory concentration: 100 nM
Compound 4: middle estimate off by 2.5-fold (0.40 log units), on the low side; the range from low to high includes it.
By their numbers in this assay, from the lowest: compound 1; then compound 3; then compound 4; then compound 2.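

In this assay, among these compounds, the first change that keeps an imidazole at this position still moves the read-out, with a 2.2-fold higher number from compound 3 to compound 4 (0.35 log units; beyond the scatter), so the presence of an imidazole alone does not set the number. The 2-(1H-imidazol-4-yl)ethyl group keeps a lower number than pyridin-4-yl, with a 2.8-fold lower number from compound 2 to compound 4 (0.45 log units; beyond the scatter), but a higher one than piperidin-4-yl, with a 7.7-fold higher number from compound 1 to compound 4 (0.89 log units; beyond the scatter). Nothing available explains these steps.

Chain length and imidazole attachment change together here, so their separate shares stay open. Going by these compounds, the values of 2-(1H-imidazol-4-yl)ethoxy, 3-(1H-imidazol-1-yl)propoxy and a primary amine on the chain also remain open.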